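The compounds below may be only part of what the source reports. "The series", "measured", "known", "first", "only" and "open" are said of these compounds alone.

Working notes on the series. In a functional assay on P388 cells (Mus musculus) for antiproliferative activity (a lower number here means a stronger inhibitor, a higher number a weaker inhibitor), compound 1 (`NC(=O)c1ccc(S(=O)(=O)Nc2cccc3c(Cl)c[nH]c23)cc1`) gives 0.87 ug/mL and compound 2 (`CS(=O)(=O)Nc1ccc(S(=O)(=O)Nc2cccc3c(Cl)c[nH]c23)cc1`) gives 1.6 ug/mL while compound 3 (`NS(=O)(=O)Cc1ccc(S(=O)(=O)Nc2cccc3c(Cl)c[nH]c23)cc1`) gives 0.15 ug/mL as the lowest of the three numbers, with its gaps to both others beyond the scatter. Compound 4 (`CNS(=O)(=O)c1ccc(S(=O)(=O)Nc2cccc3c(Cl)c[nH]c23)cc1`) is still unmeasured and differs from compound 3 as follows (methylsulfamoyl in place of sulfamoylmethyl on an aromatic carbon): methylsulfamoyl in place of sulfamoylmethyl on an aromatic carbon, para to a large group.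

All three measured steps exchange the group at this same place. They show a 1.8-fold higher number from compound 1 to compound 2 (0.26 log units; within the scatter) as well as a 5.8-fold lower number from compound 1 to compound 3 (0.76 log units; beyond the scatter) and an 11-fold lower number from compound 2 to compound 3 (1.03 log units; beyond the scatter) so the group at this place can shift the number in this assay by a large margin or by none beyond the scatter. Going by the values given here, no measured compound carries methylsulfamoyl, so no step speaks for it directly. Compound 3 at 0.15 ug/mL sits at the low end of the measured range, so a modest step to a higher number is expected, although a step within the scatter remains possible. The expected step is a 2.7-fold higher number from compound 3 to compound 4 (0.43 log units; beyond the scatter) in this assay on this reasoning. The estimated value for compound 4 is 0.4 ug/mL with an expected range from 0.13 ug/mL to 1.2 ug/mL in this assay for now.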

Compound 4, half-maximal inhibitory concentration: 0.9 ug/mL
Estimate against measurement, compound 4: 2.3-fold (0.35 log units) below; the range from low to high includes it.
By their numbers in this assay, from the lowest: compound 3; then compounds 1, 4 and 2 (each within the scatter of the next).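

Sulfamoylmethyl and methylsulfamoyl carry the same atoms and the same counts under the comparison of the two structures, yet in this assay the exchange gives a 6.0-fold higher number from compound 3 to compound 4 (0.78 log units; beyond the scatter), so the number at this place depends on how those atoms are joined and not on which atoms are present. With a 1.0-fold higher number from compound 1 to compound 4 (0.01 log units; within the scatter) and a 1.8-fold lower number from compound 2 to compound 4 (0.25 log units; within the scatter), the methylsulfamoyl, carbamoyl and methanesulfonamido compounds cannot be told apart in this assay, which leaves compound 3, with the sulfamoylmethyl group, as the only one of the four set apart from all the others by steps beyond the scatter. Nothing available here gives a reason for the gap between these two arrangements of the same atoms.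

The exchange from compound 3 to compound 4 both removes the methylene link to the ring and places a methyl on the sulfonamide nitrogen, so the compounds shown do not separate these two changes. From the compounds shown here alone, an unsubstituted sulfamoyl group directly on the aromatic carbon, or a methylsulfamoylmethyl group, would be needed to tell which of them carries the step, and a longer chain such as 2-sulfamoylethyl remains open as well.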